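The compounds below may be only part of what the source reports. "The series", "measured", "known", "first", "only" and "open" are said of these compounds alone.

In a functional assay on MCF7 cells (Homo sapiens) for cytotoxicity, read by MTT assay, with a stated time of 72 h (on this read-out higher numbers stand for weaker inhibition and lower numbers for stronger inhibition), three compounds sharing one core have been measured so far. Compound 1 `O=C1C(=Cc2ccc(Cl)cc2)C(=O)N(c2ccc(Cl)cc2)N1c1ccc(Cl)cc1` gives 28500 nM, compound 2 `O=C1C(=Cc2ccc(Br)cc2)C(=O)N(c2ccc(Cl)cc2)N1c1ccc(Cl)cc1` gives 30400 nM, and compound 3 `COc1cc(C=C2C(=O)N(c3ccc(Cl)cc3)N(c3ccc(Cl)cc3)C2=O)ccc1O` gives 22800 nM. Compound 3 therefore stands level with the other two, since a 1.3-fold lower number from compound 1 to compound 3 (0.10 log units; within the scatter) and a 1.3-fold lower number from compound 2 to compound 3 (0.12 log units; within the scatter) both stay within the usual scatter of repeated measurements.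

The next compound to consider is compound 4 `COc1cccc(C=C2C(=O)N(c3ccc(Cl)cc3)N(c3ccc(Cl)cc3)C2=O)c1O`, which has the same atoms as compound 3, joined differently: 2-hydroxy-3-methoxyphenyl in place of 4-hydroxy-3-methoxyphenyl on a double-bonded chain carbon bound to a double-bonded ring carbon. The hydroxy group thus has a new place on the ring, while the group as a whole remains on the double-bonded chain carbon.

Two measured steps changed this same place, replacing a halogen-bearing ring with the 4-hydroxy-3-methoxyphenyl group, and they were small: a 1.3-fold lower number from compound 1 to compound 3 (0.10 log units; within the scatter) and a 1.3-fold lower number from compound 2 to compound 3 (0.12 log units; within the scatter). A third, bromo in place of chloro on an aromatic carbon, was also small: a 1.1-fold higher number from compound 1 to compound 2 (0.03 log units; within the scatter). Among the measured compounds shown here, none of the measured compounds shows what moving the hydroxy group does, so the evidence is only indirect and no direction can be favoured.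

The expected result is a 1.0-fold lower number from compound 3 to compound 4 (0.02 log units; within the scatter), which would be no real change beyond the scatter. For compound 4 the estimate in this assay is 22000 nM, with an expected range from 9000 nM to 45000 nM.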

Compound 4, half-maximal inhibitory concentration: 26700 nM
For compound 4 the middle estimate is 1.2-fold (0.08 log units) below the measured one; the range from low to high includes it.
By their numbers in this assay, from the lowest: compounds 3, 4, 1 and 2 (each within the scatter of the next).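

Moving the hydroxy group gives the first direct reading of where it sits on this ring: in this assay the step is small (a 1.2-fold higher number from compound 3 to compound 4 (0.07 log units; within the scatter)), so its two places here cannot be told apart. The 2-hydroxy-3-methoxyphenyl group also stands level with the halogen-bearing rings at this place (a 1.1-fold lower number from compound 2 to compound 4 (0.06 log units; within the scatter); a 1.1-fold lower number from compound 1 to compound 4 (0.03 log units; within the scatter)), so all four groups on the double-bonded chain carbon give numbers within the scatter of one another. No measurement at hand offers a reason for this flat picture.

Still open, from the compounds shown here alone, is whether any group at this place can shift the number beyond the scatter, since all four compounds carry a phenyl ring with only halogen, hydroxy or methoxy groups, and none has an amine, a carboxylic acid or a longer chain on that ring. The compounds shown also leave open what happens when the two 4-chlorophenyl groups on the shared core are replaced, for example by plain phenyl groups.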